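Replacing methylamino with morpholin-4-yl in a CDK8 series

A few compounds are considered here, and "the series" means these few. Any claim that something is new, unique, unknown or untested is made for them only; others in the source may bear on it.

Of the compounds shown here, two have so far been tested in an assay on a protein complex for inhibition of CDK8/Cyclin C (Homo sapiens), with a stated time of 1 h, tested at 10 uM; on this read-out lower numbers stand for less inhibition and higher numbers for more inhibition at the one concentration tested (going by the name of the read-out). Compound 1 `CNC(=O)/C=C/c1ccncc1-c1ccc2cccnc2c1` gives 82%, the lower of the two numbers. Compound 2 `O=C(/C=C/c1ccncc1-c1ccc2[nH]ccc2c1)N1CCOCC1` gives 97%, which lies beyond the usual scatter above compound 1; since compound 2 differs from compound 1 in more than one place, this gap cannot be credited to any single change. Compound 3 `O=C(/C=C/c1ccncc1-c1ccc2cccnc2c1)N1CCOCC1` has not yet been measured. It differs from compound 1 in one place: morpholin-4-yl in place of methylamino on a carbonyl carbon. Among the compounds with values here, no measured pair isolates this change, so its effect on the read-out is unknown from the present numbers. Given that compound 1 already gives 82%, a small upward step is expected, a number 6 percentage points higher from compound 1 to compound 3 (within the scatter), possibly within the scatter. Compound 3 is therefore estimated at 88%, with a likely range from 75% to 97%.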

Compound 3, a percentage reported as inhibition, at one concentration (the size of the read-out at that concentration, not a potency): 33%
The estimate for compound 3 lay 55 percentage points above the measured number; measured number outside the range, below it.
By their numbers in this assay, from the lowest: compound 3; then compound 1; then compound 2.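

With all else held the same, morpholin-4-yl in place of methylamino on a carbonyl carbon gives a number 49 percentage points lower from compound 1 to compound 3 (beyond the scatter) in this assay, so the group on this carbonyl carbon can strongly change the read-out. Morpholin-4-yl does not fix the number by itself: compound 2 carries it with a different group elsewhere and gives 97%, whereas compound 3 gives 33%. No measurement at hand bears on why the number falls.

The change removes the amide hydrogen and brings in a ring at once, and the compounds shown leave open which of these goes with the drop. Dimethylamino on the same carbonyl carbon, which has no amide hydrogen and no ring, and piperidin-1-yl, which has a ring without the oxygen, would help to tell these apart.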